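Notes on amide substituents: compound 2 to compound 3

The source may hold more compounds than are shown below. What is called first, only, known or untested is meant among the compounds shown, and "the series" means these compounds.

Compound 1 `CNC(=O)c1nc(-c2cc(OC)c(OC)c(OC)c2)n(-c2ccc(OC)cc2)n1`: 65%
Compound 2 `COc1ccc(-n2nc(C(=O)Nc3ccccc3C)nc2-c2cc(OC)c(OC)c(OC)c2)cc1`: 46%

In a functional assay on the whole organism for inhibition, with Rattus norvegicus as the target, read by paw edema, with stated times of 30 min and 4 h, at a dose of 0.28 mmol/kg by the oral route (a lower number here means less inhibition, a higher number more inhibition at the dose given (going by the name of the read-out)), compound 1 gives 65% and compound 2 gives 46%, so compound 2 stands lowest of the two measured numbers, with the step of a number 19 percentage points lower from compound 1 to compound 2 (beyond the scatter) beyond the scatter. Compound 3 `COc1ccc(-n2nc(C(=O)Nc3ccc(C(F)(F)F)cc3)nc2-c2cc(OC)c(OC)c(OC)c2)cc1` differs from compound 2 by 4-(trifluoromethyl)phenyl in place of 2-methylphenyl on an amide-type nitrogen. Within the data shown here, no measured step exchanges one ring for another on the amide-type nitrogen; the single measured step, a number 19 percentage points lower from compound 1 to compound 2 (beyond the scatter), bears on it only indirectly. The change is therefore expected to bring a number 1 percentage points lower from compound 2 to compound 3 (within the scatter), a step not beyond the scatter. Compound 3 is estimated at 45%, within 30% to 60%.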

Compound 3, a percentage reported as inhibition, in the whole organism at one dose (the size of the read-out at that dose, not a potency): 56%
The estimate for compound 3 lay 11 percentage points below the measured number; low and high end bracket the measured number.
By their numbers in this assay, from the lowest: compounds 2, 3 and 1 (each within the scatter of the next, the first and the last beyond it).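

In this assay, exchanging one ring for another on the amide-type nitrogen gives a number 10 percentage points higher from compound 2 to compound 3 (within the scatter), and 4-(trifluoromethyl)phenyl in place of methyl gives a number 9 percentage points lower from compound 1 to compound 3 (within the scatter), so a ring on this nitrogen does not by itself bring a step beyond the scatter. Of the two rings shown, only 2-methylphenyl stands beyond the scatter from methyl. No measured property is at hand to account for these steps.

Compounds 2 and 3 differ in both substituent and its place on the ring, so the two are not separated. Unsubstituted phenyl, benzyl or a longer alkyl chain on this nitrogen remains open.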